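Methoxy-to-nitro swap on the bis-arylidene series

The compounds below may be only part of what the source reports. "The series", "measured", "known", "first", "only" and "open" are said of these compounds alone.

Measured so far:
compound 1 `COc1ccc(/C=C2\CCC/C(=C\c3cccc([N+](=O)[O-])c3)C2=O)cc1` — 44.7 ug/mL
compound 2 `COc1cc(/C=C2\CCC/C(=C\c3cccc([N+](=O)[O-])c3)C2=O)cc(Br)c1OC` — 13.9 ug/mL
compound 3 `CCCOc1c(Br)cc(/C=C2\CCC/C(=C\c3cccc([N+](=O)[O-])c3)C2=O)cc1OC` — 2.99 ug/mL

In a functional assay on MDA-MB-231 cells (Homo sapiens) for cytotoxicity, read by MTT assay (on this read-out lower numbers stand for stronger inhibition and higher numbers for weaker inhibition), compound 1 gives the highest number of the three. Among the compounds with values here, compound 2 sits at 13.9 ug/mL, and compound 3, with 2.99 ug/mL, sits lowest; the one step that differs in a single place is a 4.6-fold lower number from compound 2 to compound 3 (0.67 log units; beyond the scatter).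

Compound 4 `O=C1/C(=C/c2ccc([N+](=O)[O-])cc2)CCC/C1=C\c1cccc([N+](=O)[O-])c1` has not been measured. It differs from compound 1 in one place: nitro in place of methoxy on an aromatic carbon. Within the data shown here, no measured step covers this change; the only single-place step in the set concerns an ethyl added to a chain carbon on the oxygen-bearing ring, and the gap from compound 1 to compound 2 involves two changes at once. There is therefore no direct basis for expecting the nitro to move the number in either direction beyond the scatter, and the estimate rests mainly on compound 1 at 44.7 ug/mL.

Compound 4 is estimated at 35 ug/mL, range 9 ug/mL to 110 ug/mL, which amounts to an expected step of a 1.3-fold lower number from compound 1 to compound 4 (0.11 log units; within the scatter).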

Compound 4, half-maximal inhibitory concentration: 8.85 ug/mL
For compound 4 the middle estimate is 4.0-fold (0.60 log units) above the measured one; the whole stated range lies above it.
By their numbers in this assay, from the lowest: compound 3; then compounds 4 and 2 (each within the scatter of the next); then compound 1.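

In this assay the change from 4-methoxyphenyl to 4-nitrophenyl gives a 5.1-fold lower number from compound 1 to compound 4 (0.70 log units; beyond the scatter) and so shows that this aromatic carbon, para to a large group, is not indifferent to the group it carries. Within the data shown here, the earlier single-place step, a 4.6-fold lower number from compound 2 to compound 3 (0.67 log units; beyond the scatter), concerned the chain on an oxygen, so this is the first single-place change in the set that replaces a group directly on the aromatic carbon. No measurement of any property of the two groups bears on this step, and the data offer no account of it.

From the compounds shown here alone, whether an amine, a carboxylic acid or a nitrile at this carbon would give a similar number remains open. Also open, going by these compounds, is whether nitro in place of methoxy would give a step of similar size on a ring that also carries bromine.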